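The source may hold more compounds than are shown below. What is called first, only, known or untested is meant among the compounds shown, and "the series" means these compounds.

The measured compounds:

- compound 1, `Cc1ccc(S(=O)(=O)N2CC(c3ccccc3)NC2=O)cc1`: 12500 nM
- compound 2, `O=C1NC(c2ccccc2)CN1S(=O)(=O)c1ccc(Cl)cc1`: 9470 nM

Going by the values given here, in a functional assay on A549 cells (Homo sapiens) for cytotoxicity (on this read-out lower numbers stand for stronger inhibition and higher numbers for weaker inhibition), compound 1 gives 12500 nM, the highest of the two numbers known so far. Compound 2 gives 9470 nM in this assay, and the step of a 1.3-fold lower number from compound 1 to compound 2 (0.12 log units; within the scatter) is too small to count as a real difference, so the two compounds look alike on this read-out.

Compound 3, `Cc1ccc(C2CN(S(=O)(=O)c3ccc(C)cc3)C(=O)N2)cc1`, has not yet been measured. It differs from compound 1 by methyl in place of hydrogen on an aromatic carbon. Among the compounds with values here, no measured pair shows this particular change. Within the data shown here, the only measured step, a 1.3-fold lower number from compound 1 to compound 2 (0.12 log units; within the scatter), concerns a different change on a different ring and stayed within the scatter; it suggests that small changes on the aromatic rings of this core have so far left the numbers in this assay roughly where they were, but it does not directly test the phenyl-to-4-methylphenyl change.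

With nothing pointing up or down, the step of a 1.0-fold lower number from compound 1 to compound 3 (0.02 log units; within the scatter) is expected to stay within the scatter. Compound 3 is therefore estimated at 12000 nM in this assay, with a likely range of 5000 nM to 30000 nM.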

Compound 3, half-maximal inhibitory concentration: > 302000 nM
Compound 3 gave a limit, no number (the forecaster's own chance of this, stated with the estimate: 10%); at least 25-fold (1.40 log units) between middle value and limit.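

In this assay, compound 3 carries a limit of the assay and not a number: the limit of > 302000 nM in this assay, at which 1 of the 3 values shown sits. Going from phenyl to 4-methylphenyl gives an at least 24-fold higher number from compound 1 to compound 3 (1.38 log units; beyond the scatter), which shows that this position, on an aromatic carbon and para to a large group, is sensitive to even one added carbon atom. The earlier pair showed nothing of the kind, since the chloro-for-methyl swap on the other ring gave only a 1.3-fold lower number from compound 1 to compound 2 (0.12 log units; within the scatter), so the aromatic rings of this core cannot be treated as equally tolerant of small changes.

This single pair leaves open whether the loss of cytotoxicity belongs to methyl alone or would also follow from other groups at the same position, such as a hydroxyl, an amine, a carboxylic acid or a longer chain such as ethyl. Going by these compounds, the limit also leaves the true size of the step unknown, and it remains open whether the same methyl would have a similar effect on the chloro-bearing compound 2.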